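The source may report more compounds than this note shows. Statements on the series, on what has been measured and on what is new or still open speak of the compounds shown alone.

Compound 1 `Cc1ccc2[nH]c(=O)c(/C=N/c3ccc(C(=O)O)cc3)cc2c1` carries a carboxy group on its core. In a functional assay, read by spectrophotometry, with a stated time of 1 h (on this read-out lower numbers stand for stronger inhibition and higher numbers for weaker inhibition), compound 1 is reported as "not active" (no number reported), with no number attached, so it cannot be placed on the scale that the other compounds define. Two related compounds do give numbers: in this assay compound 2 `O=c1[nH]c2ccccc2cc1/C=N/c1ccccc1O` gives 1660000 nM, and compound 3 `N/N=C/c1cc2ccccc2[nH]c1=O` gives 365000 nM in this assay. Compound 4 `Cc1ccc2[nH]c(=O)c(/C=N/c3ccc(S(N)(=O)=O)cc3)cc2c1` differs from compound 1 in one place: sulfamoyl in place of carboxy on an aromatic carbon. Going by the values given here, no measured pair shows such a change, so the size of the step in this assay is unknown; a modest gain on compound 1, or none beyond the scatter, seems most likely, in the weak range where compound 2 and compound 3 fall. For compound 4 the half-maximal inhibitory concentration is estimated at 600000 nM, expected between 100000 nM and 4000000 nM.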

Compound 4, half-maximal inhibitory concentration: "not active" (no number reported)
For compound 4 the study gives words and no number; no gap can be computed for the estimate.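

Compound 1 and compound 4 are both reported in this assay as words without a number, so no step can be read between them. Nothing shown bears on this result. The compounds shown leave open whether sulfamoyl in place of carboxy changes inhibition at all.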